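Aryl Replacement on a Shared Core: Expectation for Compound 3

The source may hold more compounds than are shown below. What is called first, only, known or untested is meant among the compounds shown, and "the series" means these compounds.

Compound 1 `c1ccc2c(-c3cn4ccnc4c(-c4ccc5ncn(C6CCCCC6)c5c4)n3)cccc2c1`: 20.8%
Compound 2 `Fc1ccc(-c2cn3ccnc3c(-c3ccc4ncn(C5CCCCC5)c4c3)n2)cc1`: 15.8%

In a functional assay on MDA-MB-231 cells (Homo sapiens) for inhibition, read by sulforhodamine B assay, with a stated time of 48 h, tested at 10 uM (a higher number here means more inhibition at the concentration tested (going by the name of the read-out), a lower number less inhibition), compound 2 gives 15.8%, the lowest of the two numbers measured. Its nearest neighbour is compound 1, which in this assay gives 20.8%. Among the measured compounds shown here, the one measured step between them, a number 5 percentage points lower from compound 1 to compound 2 (within the scatter), lies within the usual scatter, so the two aryl groups on the shared core have so far given numbers that cannot be told apart.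

Compound 3 `COc1ccccc1-c1cn2ccnc2c(-c2ccc3ncn(C4CCCCC4)c3c2)n1` has not yet been measured. It differs from compound 2 in one place: 2-methoxyphenyl in place of 4-fluorophenyl on an aromatic carbon. The 4-fluorophenyl leaves and a 2-methoxyphenyl enters, so that one hydrogen-bond acceptor is counted where there was none.

For the measured compounds named here, the only step that bears on this change is the one from compound 1 to compound 2, and it stayed within the scatter. With two aryl groups giving indistinguishable numbers, the expected step of a number 2.2 percentage points higher from compound 2 to compound 3 (within the scatter) for compound 3 is none beyond the scatter. Compound 3 is therefore estimated at 18% in this assay, with a range from 5% to 35%.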

Compound 3, a percentage reported as inhibition, at one concentration (the size of the read-out at that concentration, not a potency): 15.9%
Estimate against measurement, compound 3: 2.1 percentage points above; the measured number falls inside the stated range.
By their numbers in this assay, from the lowest: compounds 2, 3 and 1 (each within the scatter of the next).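

In this assay the swap of 4-fluorophenyl for 2-methoxyphenyl gives a number 0.1 percentage points higher from compound 2 to compound 3 (within the scatter) and the swap of naphthalen-1-yl for 2-methoxyphenyl gives a number 4.9 percentage points lower from compound 1 to compound 3 (within the scatter), so the number still does not separate any of the three aryl groups on the aromatic carbon next to the ring nitrogen. Among the compounds shown here, compound 3 is the first of the compounds here whose entering group brings a counted hydrogen-bond acceptor, and it is also the first with its substituent on the 2-position of the phenyl ring; neither difference takes the number beyond the scatter of compound 2. Nothing at hand offers an explanation for this result, so it stands as an observation only.

The compounds shown therefore leave open whether this position can move the number at all, since every group tested so far is an aryl ring and all three readings come from a single concentration. Also open, going by these compounds, is whether a non-aryl group on this carbon, such as a primary amine, a carboxylic acid or a longer alkyl chain, would give a number beyond the scatter.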